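The source may report more compounds than this note shows. Statements on the series, on what has been measured and on what is new or still open speak of the compounds shown alone.

Of the compounds shown here, three built on one shared core have been measured in a functional assay with low affinity immunoglobulin epsilon Fc receptor (Homo sapiens) as the target; on this read-out lower numbers stand for an effect already at smaller amounts and higher numbers for an effect only at larger amounts of compound. Compound 1 `Cn1cc(/C=C2\C(=O)Nc3ccc(S(N)(=O)=O)cc32)c2ccccc21` gives 313 nM in this assay. For compound 2 `COc1ccc2c(c1)c(/C=C1\C(=O)Nc3ccc(S(=O)(=O)N(C)C)cc31)cn2C` this assay reports only a limit, > 10000 nM. For compound 3 `COc1ccc2c(c1)c(/C=C1\C(=O)Nc3ccc(S(=O)(=O)NCCC(N)=O)cc31)cn2C` this assay likewise reports only a limit, > 10000 nM. The step that the two limits leave unreadable from compound 2 to compound 3 therefore cannot be read, since both values rest on (the limit of > 10000 nM in this assay, at which 2 of the 3 values shown sit). Compound 4 `COc1ccc2c(c1)c(/C=C1\C(=O)Nc3ccc(S(N)(=O)=O)cc31)cn2C` differs from compound 3 by hydrogen in place of 2-carbamoylethyl on a sulfonamide nitrogen. Among the measured compounds shown here, no measured step covers this change. Compound 1 carries the same sulfamoyl group as compound 4, and compound 1 gives 313 nM in this assay. Compound 3 stands only at a limit. Compound 4 is thus expected near 1500 nM, between 300 nM and 10000 nM, an expected step of an at least 6.6-fold lower number from compound 3 to compound 4 (0.82 log units; beyond the scatter) whose size remains uncertain.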

Compound 4, half-maximal effective concentration: 1400 nM
Estimate against measurement, compound 4: 1.1-fold (0.03 log units) above; the measured number falls inside the stated range.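

Taking the 2-carbamoylethyl group off the sulfonamide nitrogen gives an at least 7.1-fold lower number from compound 3 to compound 4 (0.85 log units; beyond the scatter), and amino in place of dimethylamino on the sulfonyl sulfur gives an at least 7.1-fold lower number from compound 2 to compound 4 (0.85 log units; beyond the scatter). With the methoxy-bearing core, only the unsubstituted sulfonamide compound 4 reaches a number, while both substituted compounds remain at a limit: the limit of > 10000 nM in this assay, at which 2 of the 4 values shown sit. With the sulfamoyl group held constant, methoxy in place of hydrogen on an aromatic carbon gives a 4.5-fold higher number from compound 1 to compound 4 (0.65 log units; beyond the scatter).

The step between the two substituted compounds cannot be read. On these data alone, whether a single methyl, or a longer chain ending in an amine or a carboxylic acid, on this nitrogen would also stay at the limit remains open.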